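The source may hold more compounds than are shown below. What is called first, only, known or untested is meant among the compounds shown, and "the series" means these compounds.

Notes on the series. Compound 1 `CCOC(=O)c1ccc(-c2nn(Cc3ccccn3)c3ccccc23)cc1` and compound 2 `CCOC(=O)c1ccc(-c2nn(-c3ccco3)c3ccccc23)cc1` share a core and differ only in the group on an aromatic nitrogen. In a functional assay on cells (Platelet, Homo sapiens) for inhibition (on this read-out higher numbers stand for weaker inhibition and lower numbers for stronger inhibition), compound 1 gives > 10000 nM, which is a limit of the assay and not a number. In this assay compound 2 likewise gives > 10000 nM, again a limit rather than a number. The step that the two limits leave unreadable from compound 1 to compound 2 therefore cannot be sized, since both values sit at the limit of > 10000 nM in this assay, at which 2 of the 2 values shown sit. Compound 2 thus stands only at a limit, with no number to place it against within the series.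

Compound 3 `CCCCn1nc(-c2ccc(C(=O)OCC)cc2)c2ccccc21` is the next member to be measured: butyl in place of furan-2-yl on an aromatic nitrogen. Among the measured compounds shown here, no measured step reads on this change; the one step in hand, a step that the two limits leave unreadable from compound 1 to compound 2, is itself unreadable because of the limit of > 10000 nM in this assay, at which 2 of the 2 values shown sit. Nothing in the data therefore points to a change beyond the scatter, and the most likely outcome is another limit. The expectation for compound 3 in this assay is a value of 15000 nM, within 5000 nM to 50000 nM. The expected step is a step that the limit leaves unreadable from compound 2 to compound 3, with a limit rather than a number the likeliest report.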

Compound 3, half-maximal inhibitory concentration: > 10000 nM
Compound 3 ended at the assay's limit; the forecaster's own chance of this, stated with the estimate: 80%; the middle value lies beyond the limit too.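

In this assay compound 3 gives > 10000 nM, a limit of the assay and not a number. Among the compounds shown here, no step among compound 1, compound 2 and compound 3 can be read, because the values coincide at one limit: the limit of > 10000 nM in this assay, at which 3 of the 3 values shown sit. The compounds shown leave open whether any group on the aromatic nitrogen of the shared core gives a readable number.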